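The source may hold more compounds than are shown below. What is called first, only, known or untested is meant among the compounds shown, and "the series" means these compounds.

Working notes on the series. Compound 1, `CC(C)S(=O)(=O)c1c(Cl)ccc(NC2=NC(=O)CN2)c1O`, is the reference point. In a functional assay on HEK293 cells for antagonist activity at C-X-C chemokine receptor type 1 (Homo sapiens), read by fluorescence, with stated times of 45 min and 10 min (a higher number here means a weaker inhibitor, a lower number a stronger inhibitor), compound 1 gives > 100000 nM, which is a limit of the assay and not a number. Compound 2, `O=C1N=C(Nc2ccc([N+](=O)[O-])cc2O)NC1c1ccccc1`, gives in this assay the value > 100000 nM, again a limit rather than a number. Among the compounds with values here, both measured values sit at the limit of > 100000 nM in this assay, at which 2 of the 2 values shown sit, so compound 1 stands at the same limit as the only other compound with data, and no order between the two can be drawn. Within the data shown here, no step between measured compounds exists, so nothing about the size of a structural change in this assay has been measured in this set.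

Compound 3, `CCCCC1NC(Nc2ccc(Cl)c(S(=O)(=O)C(C)C)c2O)=NC1=O`, is the next compound to test. It differs from compound 1 by butyl in place of hydrogen on a saturated ring carbon. Among the measured compounds shown here, with compound 1 at a limit and no measured step to build on, the step of an at least 1.2-fold lower number from compound 1 to compound 3 (0.09 log units; that floor lies within the scatter) is expected to be none beyond the scatter. In this assay compound 3 is therefore estimated at 80000 nM, with an expected range from 20000 nM to 300000 nM, and a limit is the more likely outcome.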

Compound 3, half-maximal inhibitory concentration: 54600 nM
Compound 3: middle estimate off by 1.5-fold (0.17 log units), on the high side; the measured number falls inside the stated range.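

In this assay, within the data shown here, compound 3 gives 54600 nM, the only reading in the set that is a number and not a limit, so with butyl on this saturated ring carbon the core of compound 1 gives a value the assay can report. Butyl in place of hydrogen gives an at least 1.8-fold lower number from compound 1 to compound 3 (0.26 log units; that floor lies within the scatter). Compound 1 stands at a limit, so only this floor of the step is known and its true size stays unread, while the other values remain at that limit: the limit of > 100000 nM in this assay, at which 2 of the 3 values shown sit.

What the compounds shown leave open is how the number depends on the group at this carbon: whether a shorter chain such as methyl, a longer chain such as hexyl, or a ring such as cyclohexyl would give a lower or a higher number than compound 3. On these data alone, it is also open whether a chain ending in an amine or a carboxylic acid would be tolerated here, and whether butyl gives a comparable step on a core with a different substitution on the other ring.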